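The source may hold more compounds than are shown below. What is called first, only, known or untested is meant among the compounds shown, and "the series" means these compounds.

Measured compounds:
compound 1, `N#CC1=C(N)Oc2c(N)cc3nc4ccccc4nc3c2C12C(=O)N(Cc1cnnn1-c1cccc(C(F)(F)F)c1)c1ccccc12`, in a functional assay on HepG2 cells (Homo sapiens) for antiproliferative activity, read by MTT assay, with a stated time of 48 h (on this read-out higher numbers stand for weaker inhibition and lower numbers for stronger inhibition), gives 15800 nM.
compound 2, `CCc1cccc(CC)c1-n1nncc1CN1C(=O)C2(C(C#N)=C(N)Oc3c(N)cc4nc5ccccc5nc4c32)c2ccccc21`, in this assay gives 16500 nM.

Both compounds share one core and differ only in the aryl group carried on an aromatic nitrogen of the triazole ring. Compound 2 stands with the highest of the two numbers, but its nearest neighbour is compound 1, and the step from the one to the other, a 1.0-fold higher number from compound 1 to compound 2 (0.02 log units; within the scatter), is within the scatter, so the two values cannot be told apart.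

Compound 3, `N#CC1=C(N)Oc2c(N)cc3nc4ccccc4nc3c2C12C(=O)N(Cc1cnnn1-c1cc(Cl)ccc1Cl)c1ccccc12`, has not yet been measured. It differs from compound 2 in one place: 2,5-dichlorophenyl in place of 2,6-diethylphenyl on an aromatic nitrogen. Among the measured compounds shown here, the only measured step that bears on this position is the exchange of aryl groups between compound 1 and compound 2, and that exchange moved the number by no more than the scatter. On that basis, the change from compound 2 to compound 3 is expected to give a 1.0-fold lower number from compound 2 to compound 3 (0.01 log units; within the scatter), with no shift beyond the scatter in either direction. The estimate for compound 3 in this assay is therefore 16000 nM, within a range from 8000 nM to 32000 nM.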

Compound 3, half-maximal inhibitory concentration: 33100 nM
For compound 3 the middle estimate is 2.1-fold (0.32 log units) below the measured one; measured number outside the range, above it.
By their numbers in this assay, from the lowest: compounds 1, 2 and 3 (each within the scatter of the next, the first and the last beyond it).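

In this assay, the aryl group on the aromatic nitrogen of the five-membered ring with 3 nitrogen now gives its first step beyond the scatter, a 2.1-fold higher number from compound 1 to compound 3 (0.32 log units; beyond the scatter), for 2,5-dichlorophenyl in place of 3-(trifluoromethyl)phenyl, although that step is only modest. The other new step, a 2.0-fold higher number from compound 2 to compound 3 (0.30 log units; within the scatter), for 2,5-dichlorophenyl in place of 2,6-diethylphenyl, stays within the scatter, so compound 2 cannot be separated from either of the other two compounds, and only the two outer compounds of this short series can be told apart. The data offer no measured explanation for the difference between these aryl groups.

As far as these compounds go, all three compounds carry a six-membered aromatic ring of carbon only with lipophilic-free simple substituents of the halogen, trifluoromethyl or ethyl kind, so it remains open how the number would respond to an amine or a carboxylic acid on that ring, or to a longer alkyl chain in place of the ring. Also open, from the compounds shown here alone, is whether moving the two chlorines, as in 3,4-dichlorophenyl, would change the number at all.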